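Chloro for methyl on the arylpiperazine of compound 2

This account rests on a few compounds, and the source may have more. Where it says the series, first, only, none or still open, it means among the compounds named here.

Compound 2 `Cc1cccc(N2CCN(C(=O)C(C)N3C(=O)CCC3=O)CC2)c1` is the weaker of the two measured compounds in a functional assay on the whole organism (strain Swiss) with Mus musculus as the target, in the maximal electroshock model, with a stated time of 1 h, at a dose of 300 mg/kg by the intraperitoneal route (on this read-out higher numbers stand for a stronger effect at the one dose given and lower numbers for a weaker effect), where compound 2 gives 0%. Among the compounds with values here, its neighbour compound 1 `CC(C(=O)N1CCN(c2ccccc2F)CC1)N1C(=O)CCC1=O` gives 50% in this assay, and the single measured step of a number 50 percentage points lower from compound 1 to compound 2 (beyond the scatter) shows that the aryl substituent alone moves the read-out widely. Compound 3 `CC(C(=O)N1CCN(c2cccc(Cl)c2)CC1)N1C(=O)CCC1=O` differs from compound 2 by chloro in place of methyl on an aromatic carbon, on an aromatic carbon meta to a large group. Within the data shown here, no measured step covers this exact exchange; since a halogenated phenyl in compound 1 gave 50%, a rise is expected, a number 25 percentage points higher from compound 2 to compound 3 (beyond the scatter), with compound 3 estimated at 25%, between 0% and 60%.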

Compound 3, a percentage reported as activity, at one dose (the size of the read-out at that dose, not a potency): 75%
Compound 3: middle estimate off by 50 percentage points, on the low side; the measured number lies above the stated range.
By their numbers in this assay, from the lowest: compound 2; then compound 1; then compound 3.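

In this assay, chloro in place of methyl on this aromatic carbon gives a number 75 percentage points higher from compound 2 to compound 3 (beyond the scatter), so a change of one heavy atom at this place spans the whole range seen so far. The 3-chlorophenyl compound also outdoes the 2-fluorophenyl one, with a number 25 percentage points higher from compound 1 to compound 3 (beyond the scatter), which makes compound 3 the strongest of the three at this dose. No evidence bearing on this result is available.

On these data alone, whether bromo, trifluoromethyl or methoxy at this place would read like chloro remains open. So does how compound 3 would fare at other doses.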